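Working notes: compound 2 to compound 3

The source may report more compounds than this note shows. Statements on the series, on what has been measured and on what is new or still open speak of the compounds shown alone.

In a functional assay on WiDr cells (Homo sapiens) for antiproliferative activity, read by sulforhodamine B assay, with a stated time of 48 h (a higher number here means a weaker inhibitor of growth, a lower number a stronger inhibitor of growth), compound 1 `COC(=O)/C=C/OC[C@H]1OCCC[C@H]1O[Si](C)(C)C(C)(C)C` gives 36000 nM as a measured value. Compound 2 `CC(C)(C)[Si](C)(C)O[C@@H]1CCCO[C@@H]1CO/C=C/CO` reads > 100000 nM which is a limit and not a number. Among the compounds with values here, the only measured step of an at least 2.7-fold higher number from compound 1 to compound 2 (0.44 log units; beyond the scatter) puts hydroxymethyl in place of methoxycarbonyl. Compound 3 `COC(=O)CCOC[C@H]1OCCC[C@H]1O[Si](C)(C)C(C)(C)C` has 2-(methoxycarbonyl)ethyl in place of 3-hydroxyprop-1-en-1-yl on an oxygen on a saturated carbon and so carries methoxycarbonyl again. Given the step of an at least 2.7-fold higher number from compound 1 to compound 2 (0.44 log units; beyond the scatter) with methoxycarbonyl leaving, a lower number is expected in this assay with its return. The expected change is an at least 2.0-fold lower number from compound 2 to compound 3 (0.30 log units; that floor lies within the scatter) and it should be modest. For compound 3 the estimated value is 50000 nM with an expected range from 20000 nM to 100000 nM in this assay.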

Compound 3, concentration for 50% growth inhibition: > 100000 nM
Compound 3 was reported as a limit; the forecaster's own chance of this, stated with the estimate: 30%; middle value at least 2.0-fold (0.30 log units) away from the limit.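

Carrying methoxycarbonyl is not enough at this position: 2-(methoxycarbonyl)ethyl in place of 2-(methoxycarbonyl)ethenyl on an oxygen on a saturated carbon gives an at least 2.7-fold higher number from compound 1 to compound 3 (0.44 log units; beyond the scatter) in this assay. Compound 3 reads > 100000 nM, which is a limit and not a number. The step between compound 2 and compound 3 cannot be read, and only 2-(methoxycarbonyl)ethenyl gives a measured value so far: the limit of > 100000 nM in this assay, at which 2 of the 3 values shown sit.

From the compounds shown here alone, how far compound 2 and compound 3 lie past that limit stays open. Also open, going by these compounds, is whether a carboxylic acid, an amide or a longer chain in place of the methyl ester would restore a measured value.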